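A few compounds are considered here, and "the series" means these few. Any claim that something is new, unique, unknown or untested is made for them only; others in the source may bear on it.

Compound 1 `COc1ccc(OC)c(/C=N/NC(=O)c2cc(OC)c(OC)c(OC)c2)c1` gives 0.1% in a functional assay on BGC-823 cells (Homo sapiens) for antiproliferative activity, read by MTT assay, tested at 1 uM; on this read-out lower numbers stand for a weaker effect and higher numbers for a stronger effect at the one concentration tested. Compound 2 `COc1cc(C(=O)N/N=C/c2ccccc2C(F)(F)F)cc(OC)c1OC` gives 22.1% in this assay. Compound 3 `COc1cc(C(=O)N/N=C/c2ccccc2F)cc(OC)c1OC` gives 51.6% in this assay.

Compound 3 holds the highest of the three numbers in this assay, beyond the scatter from compound 2 and far beyond compound 1. Compound 4 `COc1cc(C(=O)N/N=C/c2ccc(Cl)c(Cl)c2)cc(OC)c1OC` differs from compound 3 in one place: 3,4-dichlorophenyl in place of 2-fluorophenyl on a carbon with a double bond to nitrogen. Within the data shown here, the only measured step that touches this part of the molecule is a number 29.5 percentage points higher from compound 2 to compound 3 (beyond the scatter), a modest change on swapping one halogen group for another on that ring. The change to compound 4 is larger than that step, so only a loose expectation is possible. For compound 4 the estimate is 38%, within 10% to 65%, an expected a number 13.6 percentage points lower from compound 3 to compound 4 (beyond the scatter) that may well lie within the scatter.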

Compound 4, a percentage reported as inhibition, at one concentration (the size of the read-out at that concentration, not a potency): 29.6%
For compound 4 the middle estimate is 8.4 percentage points above the measured one; the measured number falls inside the stated range.
By their numbers in this assay, from the lowest: compound 1; then compounds 2 and 4 (each within the scatter of the next); then compound 3.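

At this position, the swap to 3,4-dichlorophenyl from 2-fluorophenyl brings a number 22 percentage points lower from compound 3 to compound 4 (beyond the scatter) in this assay. With compound 4, a second group tested here falls short of the 2-fluorophenyl of compound 3, and compound 2 and compound 4 lie within the scatter of each other. No available evidence accounts for this difference.

The step changes the halogen, its number and its place on the ring all at once, so their shares cannot be separated. As far as these compounds go, how an amine or a hydroxyl group on this ring would read remains open.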